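The source may report more compounds than this note shows. Statements on the series, on what has been measured and on what is new or still open speak of the compounds shown alone.

Compound 1 `C[Si](C)(C)CCOCn1c(CC(O)(COCc2ccccc2)COCc2ccccc2)cc(=O)[nH]c1=O`, compound 2 `O=c1cc(CC(COCc2ccccc2)COCc2ccccc2)[nH]c(=O)[nH]1` and compound 3 `O=c1cc(CC(O)COCc2ccccc2)[nH]c(=O)[nH]1` were each tested in a functional assay on HeLa cells (Homo sapiens) for antiproliferative activity, read by MTT assay, with a stated time of 72 h; a higher number here means a weaker inhibitor, a lower number a stronger inhibitor. Compound 1 gave only a limit, > 100000 nM. Compound 2 likewise gave only a limit, > 100000 nM. Compound 3 also gave only a limit, > 100000 nM. Compound 3 thus stands with the other two at the limit of > 100000 nM in this assay, at which 3 of the 3 values shown sit. Within the data shown here, the one measured step, a step that the two limits leave unreadable from compound 2 to compound 3, cannot be sized. Compound 4 `C[Si](C)(C)CCOCn1c(CC(O)COCc2ccccc2)cc(=O)[nH]c1=O` carries a group of 8 heavy atoms (6 carbon, 1 oxygen, 1 silicon; no ring) in place of a hydrogen atom, on an aromatic nitrogen. Among the measured compounds shown here, no measured step covers this change, though compound 1, bearing the same group, also sits at a limit. Compound 4 is therefore expected to stay at a limit, with an estimated 150000 nM, ranging from 50000 nM to 500000 nM, which would mean the step that the limit leaves unreadable from compound 3 to compound 4.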

Compound 4, half-maximal inhibitory concentration: > 100000 nM
Compound 4 was reported as a limit; the forecaster's own chance of this, stated with the estimate: 85%; the middle value lies beyond the limit too.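

Compound 1, compound 3 and compound 4 all sit at a limit, so the steps among them cannot be read: the limit of > 100000 nM in this assay, at which 4 of the 4 values shown sit.

In this assay the compounds shown leave open whether any change to these structures would give a measurable value.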